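From Amino to Hydroxyamino on a Shared Core

This account rests on a few compounds, and the source may have more. Where it says the series, first, only, none or still open, it means among the compounds named here.

Compound 1 `Nc1ncnc2c1ccn2COC(CO)CO` gives > 100000 nM in an ADME assay on HFF cells (Homo sapiens) for cytotoxicity (a higher number here means a weaker inhibitor, a lower number a stronger inhibitor), as a limit and not a number. Compound 2 `OCC(CO)OCn1cc(I)c2c(NO)ncnc21` also carries hydroxyamino and gives > 100000 nM as a limit too. Compound 3 `CCNc1ncnc2c1c(Br)cn2COC(CO)CO` gives > 100000 nM as a limit as well. Compound 1 thus stands with the others at the limit of > 100000 nM in this assay, at which 3 of the 3 values shown sit, and has no number to move from. The change hydroxy in place of hydrogen on a nitrogen on an aromatic ring puts hydroxy in place of hydrogen on a nitrogen on an aromatic ring, amino to hydroxyamino, and gives compound 4 `OCC(CO)OCn1ccc2c(NO)ncnc21` with no reading yet. Resting on compound 2 with > 100000 nM as a limit, no change beyond the scatter is expected in this assay here. The estimated step of a number no higher from compound 1 to compound 4 (the limit leaves the size open) is expected to lie within the scatter. Compound 4 is expected at 100000 nM with an estimated range from 30000 nM to 300000 nM in this reading.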

Compound 4, half-maximal inhibitory concentration: > 100000 nM
Compound 4 gave a limit, no number; the forecaster's own chance of this, stated with the estimate: 85%; the middle value sits exactly at the limit.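

In this assay compound 4 gives > 100000 nM, a limit and not a number, and its steps from compound 1 and compound 2 cannot be read. The compounds shown leave open what either change does to the reading, as all of them share one value: the limit of > 100000 nM in this assay, at which 4 of the 4 values shown sit.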